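The compounds below may be only part of what the source reports. "The series", "measured", "known", "first", "only" and "open" are said of these compounds alone.

Compound 1, `CCSC(=S)SCC(=O)c1ccc(OC)cc1OC`, gives 12600 nM in a functional assay on HeLa cells (Homo sapiens) for antiproliferative activity, read by resazurin assay; a higher number here means a weaker inhibitor, a lower number a stronger inhibitor. Compound 2, `CCSC(=S)SCC(=O)c1ccc(OC)cc1`, gives 2510 nM. Compound 3, `CCSC(=S)SCC(=O)c1cc(OC)ccc1OC`, gives 15800 nM.

Compounds 1 and 3 hold the same atoms joined differently; the difference between their two cores is not broken down here. Their two values lie within the scatter of each other. From compound 1 to compound 2 the change is hydrogen in place of methoxy on an aromatic carbon, and this brought a 5.0-fold lower number from compound 1 to compound 2 (0.70 log units; beyond the scatter).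

Compound 4, `CCSC(=S)SCC(=O)c1cccc(OC)c1`, has not yet been measured in this assay . It differs from compound 3 by hydrogen in place of methoxy on an aromatic carbon. This is the same kind of change as that from compound 1 to compound 2, but not the same: in compound 1 the leaving methoxy sits meta to a methoxy group, whereas in compound 3 it sits para to a methoxy group. Compound 4 is nonetheless expected to show a step of about a 4.5-fold lower number from compound 3 to compound 4 (0.65 log units; beyond the scatter), resting on the step seen from compound 1 to compound 2, a 5.0-fold lower number from compound 1 to compound 2 (0.70 log units; beyond the scatter). Compound 4 is therefore estimated at 3500 nM, with a range from 1500 nM to 9000 nM.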

Compound 4, half-maximal inhibitory concentration: 5010 nM
Estimate against measurement, compound 4: 1.4-fold (0.16 log units) below, within the range that was stated.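

In this assay, hydrogen in place of methoxy on an aromatic carbon gave a 3.2-fold lower number from compound 3 to compound 4 (0.50 log units; beyond the scatter), so this second core moved in the same direction as the first. Set side by side, the two steps do not differ in size beyond what repeated measurement allows: the same change on two cores in this assay, a 5.0-fold lower number (0.70 log units; beyond the scatter) from compound 1 to compound 2 and a 3.2-fold lower number (0.50 log units; beyond the scatter) from compound 3 to compound 4, 1.6-fold (0.20 log units) apart, within the scatter of two such steps. Going by these compounds alone, this shows that the change carried over between these two arrangements of the methoxy groups in this assay, but it rests on only two pairs and shows neither why the number falls nor that it would fall in the same way on any other core.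

The compounds shown leave open whether the step would hold if the remaining methoxy group gave way to a different group, such as a chlorine atom, an amine or a carboxylic acid. They also leave open how a longer chain in place of the ethyl group on sulfur would alter the number, and whether the step would survive that change.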